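A Second Methyl on the Framework of Compound 1

The source may hold more compounds than are shown below. What is called first, only, known or untested is meant among the compounds shown, and "the series" means these compounds.

Compound 1 `Cc1cc(S(=O)(=O)/N=C(\N)n2nccc2-c2ccccc2)c(SCc2ccccc2)cc1Cl` was tested in a functional assay on HeLa cells (Homo sapiens) for cytotoxicity, read by MTT assay, with a stated time of 72 h (on this read-out higher numbers stand for weaker inhibition and lower numbers for stronger inhibition), where compound 1 gives 5000 nM. Compound 2 `Cc1cc(-c2ccccc2)n(/C(N)=N/S(=O)(=O)c2cc(C)c(Cl)cc2SCc2ccccc2)n1` differs from it only by a methyl in place of hydrogen on an aromatic carbon, and in this assay compound 2 gives 5000 nM; the step is no change at the digits printed from compound 1 to compound 2 (within the scatter). Compound 1 thus stands level with compound 2 on the numbers shown, and no other measured neighbour exists to compare it against.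

Compound 3 `Cc1cc(S(=O)(=O)/N=C(\N)n2nccc2-c2ccccc2)c(SCc2ccccc2C)cc1Cl` is the next variation: methyl in place of hydrogen on an aromatic carbon. For the measured compounds named here, the one measured step that bears on this change, from compound 1 to compound 2, also added a methyl to an aromatic carbon, though on a different ring, and it produced no change at the digits printed from compound 1 to compound 2 (within the scatter). On that slim basis a methyl at this second site is expected to leave this assay largely unchanged, and the expected step is no change at the digits printed from compound 1 to compound 3 (within the scatter). Compound 3 is therefore estimated at 5000 nM, with a range from 2500 nM to 10000 nM.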

Compound 3, half-maximal inhibitory concentration: 17000 nM
Compound 3: middle estimate off by 3.4-fold (0.53 log units), on the low side, outside the stated range (above it).
By their numbers in this assay, from the lowest: compounds 1 and 2 (each within the scatter of the next); then compound 3.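

Changing benzyl to 2-methylbenzyl gives, in this assay, a 3.4-fold higher number from compound 1 to compound 3 (0.53 log units; beyond the scatter), so this added methyl weakens inhibition modestly. A methyl in place of hydrogen on an aromatic carbon is therefore not a neutral change across this framework: the same kind of swap on another ring gave no change at the digits printed from compound 1 to compound 2 (within the scatter), so the effect depends on where the methyl sits. Nothing measured here explains why the two sites differ.

Going by these compounds, with a single group tested at this position, it remains open whether the result is specific to methyl or would extend to other groups, such as a chlorine atom, a methoxy group or an amine. On these data alone, it is also open how a methyl at another carbon of the same ring would compare.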